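The compounds below may be only part of what the source reports. "The series", "measured", "known", "first", "only" and "open" are said of these compounds alone.

Compound 1 `COc1ccc(C(=O)Nc2ccccc2C)cc1OC1CCCC1` gives 300 nM in an assay on isolated protein for inhibition of phosphodiesterase 4A (Sus scrofa); on this read-out lower numbers stand for stronger inhibition and higher numbers for weaker inhibition; compound 2 `COc1ccc(C(=O)Nc2ccncc2)cc1OC1CCCC1` gives 800 nM in this assay. Among the compounds with values here, compound 2 thus holds the higher of the two numbers, and its only measured neighbour is reached by a 2.7-fold higher number from compound 1 to compound 2 (0.43 log units; beyond the scatter). Compound 3 `COc1ccc(C(=O)Nc2cnccn2)cc1OC1CCCC1` carries pyrazin-2-yl in place of pyridin-4-yl on an amide-type nitrogen. Within the data shown here, no measured step tests this exact exchange; the one step in hand replaced a different ring on the same nitrogen and moved the number only modestly, so a comparably modest shift, most likely upward, is expected, a 1.5-fold higher number from compound 2 to compound 3 (0.18 log units; within the scatter). Compound 3 is therefore estimated at 1200 nM, within 400 nM to 4000 nM.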

Compound 3, half-maximal inhibitory concentration: 250 nM
Estimate against measurement, compound 3: 4.8-fold (0.68 log units) above; the whole stated range lies above it.
By their numbers in this assay, from the lowest: compounds 3 and 1 (each within the scatter of the next); then compound 2.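

Pyrazin-2-yl in place of pyridin-4-yl on the amide-type nitrogen gives a 3.2-fold lower number from compound 2 to compound 3 (0.51 log units; beyond the scatter) in this assay and shows that this position distinguishes between two six-membered aromatic rings with the same number of heavy atoms. Against 2-methylphenyl, the same ring gives a 1.2-fold lower number from compound 1 to compound 3 (0.08 log units; within the scatter) and so shows that a ring with hetero atoms need not give a higher number than compound 1 here. No measurement at hand explains the gap between the two hetero-aromatic rings. From the compounds shown here alone, whether pyridin-2-yl or pyrimidin-2-yl behaves like pyrazin-2-yl remains open, as does the effect of a saturated ring such as piperidin-4-yl at this place.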